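Trading methoxy for bromo on a weakly active compound

The compounds below may be only part of what the source reports. "The series", "measured", "known", "first", "only" and "open" are said of these compounds alone.

In a functional assay on BGC-823 cells (Homo sapiens) for inhibition, read by MTT assay, with a stated time of 72 h (on this read-out lower numbers stand for stronger inhibition and higher numbers for weaker inhibition), compound 1 `O=C(NCc1ccc(NC(=O)c2cc(F)ccc2N2CCCC2)cc1)OCc1cccnc1` gives 14800 nM. Compound 2 `COc1ccc(N2CCCC2)c(C(=O)Nc2ccc(CNC(=O)OCc3cccnc3)cc2)c1` stands only at a limit of the assay, > 100000 nM. Compound 3 `O=C(NCc1ccc(NC(=O)c2cc(Br)ccc2N2CCCC2)cc1)OCc1cccnc1` replaces the methoxy of compound 2 with bromo: bromo in place of methoxy on an aromatic carbon. For the measured compounds named here, the one measured step that bears on this change is the swap of fluoro for methoxy, an at least 6.7-fold higher number from compound 1 to compound 2 (0.82 log units; beyond the scatter), which lies beyond the scatter. Removing methoxy should undo at least part of that step, and bromo takes the place held by fluoro in compound 1, which gives 14800 nM. The expected change is an at least 5.0-fold lower number from compound 2 to compound 3 (0.69 log units; beyond the scatter), towards a lower number. For compound 3 the estimated value is 20000 nM, with an expected range from 6000 nM to 60000 nM.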

Compound 3, half-maximal inhibitory concentration: > 100000 nM
Compound 3 ended at the assay's limit; the forecaster's own chance of this, stated with the estimate: 15%; middle value at least 5.0-fold (0.69 log units) from the limit.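

In this assay, swapping fluoro for bromo on this carbon, para to a pyrrolidin-1-yl group, gives an at least 6.7-fold higher number from compound 1 to compound 3 (0.82 log units; beyond the scatter). Removing methoxy is therefore not enough to restore a readable value, and among the three groups shown, only fluoro gives one. The step between compound 2 and compound 3 cannot be read, because both end at the limit of the assay: the limit of > 100000 nM in this assay, at which 2 of the 3 values shown sit.

On these data alone, how bromo and methoxy rank against each other stays open. So does what chloro or an amine on this carbon would give.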